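Furanoyl to benzoyl on the exocyclic enone of the penicillanate core

This account rests on a few compounds, and the source may have more. Where it says the series, first, only, none or still open, it means among the compounds named here.

Going by the values given here, compound 1 `CC1(C)S[C@@H]2/C(=C\C(=O)c3ccco3)C(=O)N2[C@H]1C(=O)OC(c1ccccc1)c1ccccc1` is the only member of the set with a numerical result: in a functional assay on A-375 cells (Homo sapiens) for cytotoxicity, read by MTT assay, with a stated time of 48 h (on this read-out higher numbers stand for weaker inhibition and lower numbers for stronger inhibition), compound 1 gives 26000 nM. The remaining result is a limit. Compound 2 `CC1(C)S[C@@H]2C/C(=C\C(=O)c3ccccc3)C(=O)N2[C@H]1C(=O)OC(c1ccccc1)c1ccccc1` is reported in this assay only as > 100000 nM, a limit of the assay and not a number (the limit of > 100000 nM in this assay, at which 1 of the 2 values shown sits). Among the compounds with values here, no step between measured compounds is available, so compound 1 stands alone as the one fixed point.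

Compound 3 `CC1(C)S[C@@H]2/C(=C\C(=O)c3ccccc3)C(=O)N2[C@H]1C(=O)OC(c1ccccc1)c1ccccc1` is the benzoyl counterpart of compound 1: the change is phenyl in place of furan-2-yl on a carbonyl carbon. Within the data shown here, nothing measured bears directly on this exchange, and compound 2, the only other benzoyl compound, carries a different core and returns only a limit.

The expected step is small and, if anything, toward weaker inhibition: from compound 1 to compound 3 an estimated 1.7-fold higher number from compound 1 to compound 3 (0.24 log units; within the scatter) in this assay. For compound 3 the estimated value in this assay is 45000 nM, in a range from 15000 nM to 150000 nM, with a fair chance that only a limit is reported.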

Compound 3, half-maximal inhibitory concentration: 22800 nM
Compound 3: middle estimate off by 2.0-fold (0.30 log units), on the high side; low and high end bracket the measured number.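

In this assay, phenyl in place of furan-2-yl on a carbonyl carbon gives a 1.1-fold lower number from compound 1 to compound 3 (0.06 log units; within the scatter), so the two aromatic rings cannot be told apart at this position. The oxygen of the furan-2-yl group, the one hydrogen-bond acceptor that leaves with this change, is therefore not required for a numerical reading on the core of compound 1, and compound 3 now gives a second fixed point on that core alongside compound 1. The benzoyl group on this core is thus compatible with a numerical reading, while compound 2, which carries benzoyl on a different core, remains a limit of the assay and not a number: the limit of > 100000 nM in this assay, at which 1 of the 3 values shown sits.

The compounds shown leave open whether this insensitivity extends beyond unsubstituted aromatic rings, for instance to a pyridine ring, an aminophenyl group or a simple alkyl chain on the same carbonyl carbon. They also leave open how much of the reading depends on the diphenylmethyl ester, since a free carboxylic acid in its place does not appear among them.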